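From compound 3 to compound 4: chloro in place of hydrogen

The compounds below may be only part of what the source reports. "The series", "measured", "known", "first", "only" and "open" are said of these compounds alone.

Measured so far in a physicochemical assay for metabolic stability, read by HPLC, in phosphate buffer, at pH 7.3; on this read-out lower numbers stand for a shorter-lived compound and higher numbers for a longer-lived compound
- compound 1 `CCCCCCCCCCCCCCCCOC(=O)Oc1ccc(COP(=O)(OCc2ccc(OC(=O)CC)cc2)OP(=O)(O)OP(=O)(O)OC[C@@H]2O[C@H](n3cc(F)c(N)nc3=O)CS2)cc1` (45 h)
- compound 2 `CCCCCCCCCCCCCCCCOC(=O)Oc1ccc(COP(=O)(OCc2ccc(OC(=O)CCCC)cc2)OP(=O)(O)OP(=O)(O)OC[C@H]2O[C@@H](n3cc(/C=C/Br)c(=O)[nH]c3=O)C[C@@H]2O)cc1` (62 h)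
- compound 3 `CCCCCCCCCCCCCCCCOC(=O)Oc1ccc(COP(=O)(OCc2ccc(OC(=O)CC)cc2)OP(=O)(O)OP(=O)(O)OC[C@H]2O[C@@H](n3ccc(=O)[nH]c3=O)C[C@H]2N=[N+]=[N-])cc1` (68 h)

Compound 3 (68 h) stands within the scatter of both other compounds, so the three values cannot be ranked. Among the measured compounds shown here, no pair of measured compounds differs in one place only, so the data show no single-change step. Compound 4 `CCCCCCCCCCCCCCCCOC(=O)Oc1ccc(COP(=O)(OCc2ccc(OC(=O)CC)cc2)OP(=O)(O)OP(=O)(O)OC[C@H]2O[C@@H](n3cc(Cl)c(=O)[nH]c3=O)C[C@H]2N=[N+]=[N-])cc1` departs from compound 3 by one change: chloro in place of hydrogen on an aromatic carbon. Given the narrow spread from compound 1 (45 h) to compound 3 (68 h), no step beyond the scatter is expected in this assay, in either direction. The estimated step is a 1.0-fold lower number from compound 3 to compound 4 (0.02 log units; within the scatter), within the scatter. Compound 4 is expected at 65 h (estimated range 35 h to 115 h).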

Compound 4, half-life: 67 h
Beside the measured number, compound 4's estimate is 1.0-fold (0.01 log units) below it; the measured number falls inside the stated range.
By their numbers in this assay, from the lowest: compounds 1, 2, 4 and 3 (each within the scatter of the next).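

In this assay, among the compounds shown here, chloro in place of hydrogen on an aromatic carbon of the six-membered aromatic ring with 2 nitrogen gives a 1.0-fold lower number from compound 3 to compound 4 (0.01 log units; within the scatter), the first single-change step. This position therefore accepts one chlorine with the rest of the structure unchanged and no step beyond the scatter. No measurement at hand offers a reason for this result.

On these data alone, whether a methyl, an amine or a carboxylic acid on this same aromatic carbon would stay within the scatter remains open. Also open, as far as these compounds go, is whether chloro behaves alike on the core of compound 1.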